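From hydroxy to carboxy on the shared core

The source may hold more compounds than are shown below. What is called first, only, known or untested is meant among the compounds shown, and "the series" means these compounds.

In a functional assay on Hep 3B2 cells (Homo sapiens) for antiproliferative activity, read by MTT assay, with a stated time of 24 h (a lower number here means a stronger inhibitor, a higher number a weaker inhibitor), compound 1 `Cc1ccc2nc(C(=O)Nc3c(F)cc(-c4cccc(F)c4)cc3F)c(C)c(O)c2c1` gives > 100000 nM, which is a limit of the assay and not a number. Compound 2 `Cc1c(C(=O)Nc2c(F)cc(-c3cccc(F)c3)cc2F)nc2ccc(OC(F)(F)F)cc2c1O` gives 85500 nM. Compound 3 `Cc1ccc2nc(C(=O)Nc3c(F)cc(-c4cccc(F)c4)cc3F)c(C)c(C(=O)O)c2c1` carries carboxy in place of hydroxy on an aromatic carbon, opposite the ring nitrogen: carboxy in place of hydroxy on an aromatic carbon. For the measured compounds named here, the only measured step, an at least 1.1-fold lower number from compound 1 to compound 2 (0.06 log units; that floor lies within the scatter), concerns a different place on the core, and its floor lies within the scatter, so it offers little guidance. An estimated at least 4.0-fold lower number from compound 1 to compound 3 (0.60 log units; beyond the scatter) is expected, towards a lower number, though another limit remains possible. For compound 3 the expected value is 25000 nM, with an estimated range from 3000 nM to 100000 nM.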

Compound 3, half-maximal inhibitory concentration: 31600 nM
For compound 3 the middle estimate is 1.3-fold (0.10 log units) below the measured one; measured number inside the range.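

On the shared core, the position opposite the ring nitrogen responds to the group it carries: in this assay carboxy in place of hydroxy gives an at least 3.1-fold lower number from compound 1 to compound 3 (0.50 log units; beyond the scatter) at this place. The earlier step, at a different place, has a floor within the scatter, whereas this one is the first shown to reach beyond it. Compound 1 stands at a limit of the assay, and the full size of this step stays unknown because only a floor can be read: the limit of > 100000 nM in this assay, at which 1 of the 3 values shown sits.

As far as these compounds go, whether an amine or a methyl ester at this position would give a lower or a higher number remains open.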